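From methoxy to fluoro on compound 1

The compounds below may be only part of what the source reports. "The series", "measured", "known", "first", "only" and "open" are said of these compounds alone.

In an ADME assay on HCT-116 cells (Homo sapiens) for cytotoxicity, read by CellTiter-Glo, with a stated time of 72 h (on this read-out higher numbers stand for weaker inhibition and lower numbers for stronger inhibition), compound 1 `COc1ccc(-c2cccc(S(=O)(=O)N3CCC(N4CCC(C)CC4)CC3)c2)cc1` gives > 5000 nM as its result, and this is a limit of the assay, not a number. Compound 2 `CC(=O)Nc1ccc(S(=O)(=O)N2CCC(N3CCC(C)CC3)CC2)c2ccccc12` gives > 10000 nM in this assay and that is a limit too. Compound 1 therefore stands at a limit, with no true number beside it for comparison.

Compound 3 `CC1CCN(C2CCN(S(=O)(=O)c3cccc(-c4ccc(F)cc4)c3)CC2)CC1` keeps the core of compound 1 but has fluoro in place of methoxy on an aromatic carbon, para to a large group, so 4-methoxyphenyl becomes 4-fluorophenyl fluoro in place of methoxy on an aromatic carbon in the structure. Among the measured compounds shown here, no measured pair of compounds shows what a change of this kind does here. Because compound 1 gives > 5000 nM as a limit, the expectation starts from that limit and not from a number. The estimated step that the limit leaves unreadable from compound 1 to compound 3 is expected to stay within the usual scatter, with neither direction favoured. For compound 3 the estimate is 7000 nM as a central value, with an expected range from 2500 nM to 20000 nM in this assay and a good chance that only a limit is reported.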

Compound 3, half-maximal inhibitory concentration: > 5000 nM
Compound 3: no number, only a limit (the forecaster's own chance of this, stated with the estimate: 75%); the middle value lies beyond the limit too.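

In this assay compound 3 gives > 5000 nM, which is a limit of the assay and not a number. Compound 1 also stands at a limit, so no step can be read for fluoro in place of methoxy. The compounds shown leave open whether this change alters cytotoxicity at all, and what true value compound 1, compound 2 or compound 3 would have.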